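This account rests on a few compounds, and the source may have more. Where it says the series, first, only, none or still open, it means among the compounds named here.

Measured so far in a functional assay on MGC-803 cells (Homo sapiens) for cytotoxicity, read by MTT assay, with a stated time of 48 h; a higher number here means a weaker inhibitor, a lower number a stronger inhibitor:
- compound 1 `O=C(CSc1ccc([N+](=O)[O-])cc1)N1N=C(c2cc3ccccc3oc2=O)C[C@@H]1c1ccccc1C(F)(F)F` gives 7580 nM
- compound 2 `O=C(CSc1ncccn1)N1N=C(c2cc3ccccc3oc2=O)C[C@@H]1c1ccc(C(F)(F)F)cc1` gives 2890 nM

Compound 2 holds the lower of the two numbers, and its gap to compound 1 lies beyond the scatter. Compound 3 `O=C(CSc1ccc([N+](=O)[O-])cc1)N1N=C(c2cc3ccccc3oc2=O)C[C@@H]1c1ccc(C(F)(F)F)cc1` comes next, with the change 4-nitrophenyl in place of pyrimidin-2-yl on a sulfur and thus 4-nitrophenyl in place of pyrimidin-2-yl on a sulfur. Among the compounds with values here, no measured pair isolates this change. Compound 1, which also has 4-nitrophenyl on a sulfur, gives 7580 nM and so points to a small expected rise in this assay, probably within the scatter. The estimated 1.5-fold higher number from compound 2 to compound 3 (0.16 log units; within the scatter) is therefore modest. For compound 3 the expected value is 4200 nM with an estimated range of 1700 nM to 9500 nM in this read-out.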

Compound 3, half-maximal inhibitory concentration: 10200 nM
Compound 3: middle estimate off by 2.4-fold (0.39 log units), on the low side; measured number above the stated range.
By their numbers in this assay, from the lowest: compound 2; then compounds 1 and 3 (each within the scatter of the next).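

In this assay the sulfur position now has a clean comparison: 4-nitrophenyl in place of pyrimidin-2-yl gives a 3.5-fold higher number from compound 2 to compound 3 (0.55 log units; beyond the scatter), so the group on this sulfur changes the read-out. With 4-nitrophenyl held on the sulfur, 4-(trifluoromethyl)phenyl in place of 2-(trifluoromethyl)phenyl on the saturated ring carbon gives a 1.3-fold higher number from compound 1 to compound 3 (0.13 log units; within the scatter), a step that does not separate the two groups. Nothing available accounts for either step. Still open, on these data alone, is whether pyrimidin-2-yl keeps its lower number alongside 2-(trifluoromethyl)phenyl, and how an amine or a simple ethyl chain on the sulfur would read.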